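The compounds below may be only part of what the source reports. "The series", "measured", "known", "first", "only" and "open" are said of these compounds alone.

In an ADME assay on HEK-293T cells (Homo sapiens) for inhibition, read by CCK-8 assay, with a stated time of 48 h, tested at 20 uM (a higher number here means more inhibition of growth at the concentration tested, a lower number less inhibition of growth), compound 1 `Cc1ccc(S(=O)(=O)Oc2ccccc2/C=C(\C#N)C(=O)Nc2nnc(C)s2)cc1` gives 35%, compound 2 `Cc1ccc(S(=O)(=O)Oc2ccccc2/C=C(\C#N)C(=O)Nc2nnc(Cc3cccc(F)c3)s2)cc1` gives 9% and compound 3 `Cc1ccc(S(=O)(=O)Oc2ccccc2/C=C(\C#N)C(=O)Nc2nnc(Cc3ccc(Cl)cc3)s2)cc1` gives 20%, which puts compound 3 second highest of the three. Compound 4 `N#C/C(=C\c1ccccc1OS(=O)(=O)c1ccc(F)cc1)C(=O)Nc1nnc(Cc2ccc(Cl)cc2)s1` differs from compound 3 in one place: fluoro in place of methyl on an aromatic carbon. The (4-methylphenyl)sulfonyl becomes (4-fluorophenyl)sulfonyl. Among the compounds with values here, no measured step touches this group. The nearest guides change a different place, a number 15 percentage points lower from compound 1 to compound 3 (beyond the scatter) and a number 11 percentage points higher from compound 2 to compound 3 (beyond the scatter), so they show only how far this assay moves in this small set and give no direction for the new change. No step beyond the scatter is therefore expected, and the estimated change is no change at the digits printed from compound 3 to compound 4 (within the scatter). The estimate for compound 4 is 20%, with an expected range from 8% to 34%.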

Compound 4, percent growth inhibition at one concentration: 14%
The estimate for compound 4 lay 6 percentage points above the measured number, and the stated range covers the measured number.
By their numbers in this assay, from the lowest: compounds 2, 4 and 3 (each within the scatter of the next, the first and the last beyond it); then compound 1.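

Changing the (4-methylphenyl)sulfonyl to (4-fluorophenyl)sulfonyl gives, in this assay, a number 6 percentage points lower from compound 3 to compound 4 (within the scatter). Within the data shown here, this is the first reading at this position, and it shows that exchanging methyl for fluoro on this aromatic carbon, para to a large group, causes no clear change in growth inhibition in the setting of compound 3. No measurement here explains this result.

As far as these compounds go, what an amine, a methoxy group or a carboxylic acid would do in this place stays open. So does whether the same exchange would read alike on compound 1 or compound 2.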